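A few compounds are considered here, and "the series" means these few. Any claim that something is new, unique, unknown or untested is made for them only; others in the source may bear on it.

Within the data shown here, in a functional assay (trachea) with Cavia porcellus as the target (on this read-out higher numbers stand for an effect only at larger amounts of compound and lower numbers for an effect already at smaller amounts), compound 1 (`CCCn1c(=O)n(CCN(C)C)c(=O)c2[nH]cnc21`) gives 2700 nM and compound 2 (`CCCn1c(=O)n(C)c(=O)c2[nH]cnc21`) gives 1600 nM, so the only two numbers available lie within the usual scatter of each other. Compound 3 (`CCCn1c(=O)n(C)c(=O)c2c1ncn2CC(N)=O`) differs from compound 2 in one place: carbamoylmethyl in place of hydrogen on an aromatic nitrogen. Among the measured compounds shown here, no measured compound carries a group on that nitrogen, so a direct step is lacking. The nearest evidence is a 1.7-fold lower number from compound 1 to compound 2 (0.23 log units; within the scatter), where hydrogen replaces (dimethylamino)methyl on a saturated chain carbon bound to an aromatic nitrogen. On that evidence, a modest step toward a higher number is expected in this assay, not a large one. The expected change is a 1.9-fold higher number from compound 2 to compound 3 (0.27 log units; within the scatter). For compound 3 the estimated value is 3000 nM, with an expected range from 1000 nM to 10000 nM.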

Compound 3, half-maximal effective concentration: > 100000 nM
Compound 3 gave a limit, no number; the forecaster's own chance of this, stated with the estimate: 10%; middle value at least 33-fold (1.52 log units) from the limit.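

Compound 3 gives a limit of the assay and no number: the limit of > 100000 nM in this assay, at which 1 of the 3 values shown sits. In this assay the change on this aromatic nitrogen is not a small one, with an at least 62-fold higher number from compound 2 to compound 3 (1.79 log units; beyond the scatter), whereas the earlier change on a saturated chain carbon bound to an aromatic nitrogen, a 1.7-fold lower number from compound 1 to compound 2 (0.23 log units; within the scatter), gave no such sign. The earlier compounds shown here therefore showed tolerance only for that chain change, and carbamoylmethyl on this ring nitrogen now marks a place where a substituent can shift the read-out sharply.

Only carbamoylmethyl is shown at this nitrogen, so it stays open whether the shift follows from any group placed there or from this group in particular. A plain methyl, a longer chain, an amine or a carboxylic acid on the same nitrogen would separate those two readings.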